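This account rests on a few compounds, and the source may have more. Where it says the series, first, only, none or still open, it means among the compounds named here.

Compound 1 `O=C1/C(=C/c2ccccc2)CCC/C1=C\c1ccc(Cl)cc1` and compound 3 `O=C(/C=C(O)/C=C/c1ccc(O)cc1)c1ccccc1O` have different cores, and the difference between the two cores is not broken down here. In an assay on isolated protein for inhibition of Alpha glucosidase (Homo sapiens), with stated times of 5 min and 15 min, tested at 50 uM (a lower number here means less inhibition, a higher number more inhibition at the concentration tested (going by the name of the read-out)), compound 1 gives 27.6%, while compound 3 gives 20.4%. Compound 2 `O=C(/C=C(O)/C=C/c1ccc(O)cc1)c1cc(Cl)ccc1O` carries one more chlorine than compound 3, a change of chloro in place of hydrogen on an aromatic carbon, and in this assay compound 2 gives 45.3%, a step of a number 24.9 percentage points higher from compound 3 to compound 2 (beyond the scatter). Compound 4 `O=C1/C(=C/c2ccccc2)CCC/C1=C\c1ccc(Cl)c(Cl)c1` is made from compound 1 by the same kind of change, (chloro in place of hydrogen on an aromatic carbon), though the new chlorine sits ortho to a chloro group rather than para to a hydroxy group. Because the step of a number 24.9 percentage points higher from compound 3 to compound 2 (beyond the scatter) was a modest rise, a gain of similar size is expected for compound 4, namely a number 14.4 percentage points higher from compound 1 to compound 4 (beyond the scatter). The estimated inhibition of compound 4 is therefore 42%, expected between 25% and 58%.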

Compound 4, a percentage reported as inhibition, at one concentration (the size of the read-out at that concentration, not a potency): 48.4%
The estimate for compound 4 lay 6.4 percentage points below the measured number, and the stated range covers the measured number.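

In this assay, adding the second chlorine gives a number 20.8 percentage points higher from compound 1 to compound 4 (beyond the scatter). Among the compounds shown here, the same change therefore carries over from one core to the other with a similar gain: the same change on two cores in this assay, a number 24.9 percentage points higher (beyond the scatter) from compound 3 to compound 2 and a number 20.8 percentage points higher (beyond the scatter) from compound 1 to compound 4, 4.1 percentage points apart, within the scatter of two such steps This rests on only two pairs of compounds, and in compound 4 the new chlorine sits ortho to a chloro group, a setting that compound 2 lacks, so it does not show that every position or core would respond alike. The read-out also comes from a single concentration, so it does not give potency.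

The compounds shown leave open whether a bromine, a methoxy group or an amine in the same place would give a similar gain. They also leave open whether a chlorine elsewhere on either ring would do so.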